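Chloro in Place of Methyl and Expected Clearance

The compounds below may be only part of what the source reports. "The series", "measured", "known", "first", "only" and "open" are said of these compounds alone.

Of the compounds shown here, three have so far been tested in an ADME assay on microsomes from liver (Homo sapiens) for metabolic stability; on this read-out lower numbers stand for slow clearance and higher numbers for fast clearance. Compound 1, `Cc1cccnc1N(C(=O)N1CCC(c2ccccc2)CC1)[C@@H]1CCCNC1`, is the one whose result is only a limit: in this assay compound 1 gives < 8 mL.min-1.g-1, which marks the edge of what the assay can report rather than a measured number. Compound 2, `COc1ccc(CCC(=O)N(c2nccc3ccccc23)[C@@H]2CCCNC2)cc1`, gives 21 mL.min-1.g-1 in this assay. Compound 3, `Cc1ccc2c(N3CCN(C(=O)N(c4nccc5ccccc45)[C@@H]4CCCNC4)CC3)noc2c1`, gives 12.9 mL.min-1.g-1 in this assay. Where compound 1 stands is therefore described only by the limit of < 8 mL.min-1.g-1 in this assay, at which 1 of the 3 values shown sits.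

Compound 4, `O=C(N1CCC(c2ccccc2)CC1)N(c1ncccc1Cl)[C@@H]1CCCNC1`, has not yet been measured. It differs from compound 1 in one place: chloro in place of methyl on an aromatic carbon. For the measured compounds named here, no measured pair in this set shows what such a change does, so the expectation rests on compound 1 alone. The step from compound 1 to compound 4 is expected to be small, with any movement more likely toward faster clearance than slower, and is estimated as a number no lower from compound 1 to compound 4 (the limit leaves the size open). Compound 4 is accordingly expected to give about 8 mL.min-1.g-1, in a range from 4 mL.min-1.g-1 to 16 mL.min-1.g-1.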

Compound 4, intrinsic clearance in microsomes in the Homo sapiens assay: < 9.3 mL.min-1.g-1
Compound 4: only a limit was reported (the forecaster's own chance of this, stated with the estimate: 50%); the middle value lies beyond the limit too.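

For the compounds shown here, compound 1 and compound 4 each gave only a limit in the Homo sapiens assay, and no step between them can be read. In a physicochemical assay for lipophilicity, using the shake flask method (on this read-out lower numbers stand for lower lipophilicity and higher numbers for higher lipophilicity), compound 1 gives 0.7 and compound 4 gives 0.9. The compounds shown leave open whether chloro in place of methyl alters clearance at all.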